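This account rests on a few compounds, and the source may have more. Where it says the series, first, only, none or still open, it means among the compounds named here.

Series notes, halogen exchange on the shared core

Compound 1 `CC(C)Nc1nc(O)c2cc(Cl)ccc2n1` and compound 2 `Oc1nc(NCC2CCCCC2)nc2ccc(Cl)cc12` carry the same chloro-bearing core; the difference between the two cores is not broken down here. Among the measured compounds shown here, in a functional assay (ileum) for inhibition, with Cavia porcellus as the target (a lower number here means a stronger inhibitor, a higher number a weaker inhibitor), compound 1 gives 74100 nM, and compound 2 gives 23900 nM in this assay, the lowest of the three numbers so far, with the gap to compound 1 beyond the scatter and the gap to compound 3 within it.

Compound 3 `CC(C)Nc1nc(O)c2cc(I)ccc2n1` is compound 1 with the change (iodo in place of chloro on an aromatic carbon). In this assay compound 3 gives 44100 nM, so the step of a 1.7-fold lower number from compound 1 to compound 3 (0.23 log units; within the scatter), which is within the scatter; this change is not, on its own, a clear improvement.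

Compound 4 `Oc1nc(NCC2CCCCC2)nc2ccc(I)cc12` is the unmeasured partner: compound 2 with the change (iodo in place of chloro on an aromatic carbon). The change occurs twice among these compounds, and its place is described in identical words for both pairs, so it is the same change made on two cores.

For the measured compounds named here, for compound 4 the expected step is a 1.6-fold lower number from compound 2 to compound 4 (0.20 log units; within the scatter), close to the earlier one, because the only precedent is the step of a 1.7-fold lower number from compound 1 to compound 3 (0.23 log units; within the scatter), and a single within-scatter step gives no ground to expect more. Whether the change behaves alike on the second core cannot be told from compound 1 and compound 3 alone. Compound 4 is estimated at 15000 nM, with the likely range from 7000 nM to 32000 nM.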

Compound 4, half-maximal inhibitory concentration: 26000 nM
Compound 4: the middle estimate sits 1.7-fold (0.24 log units) below what was measured, within the range that was stated.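

In this assay the exchange of chloro for iodo on the second core gives a 1.1-fold higher number from compound 2 to compound 4 (0.04 log units; within the scatter), so on this core too the change produces no clear shift in the number. Set side by side, the two steps do not differ: the same change on two cores in this assay, a 1.7-fold lower number (0.23 log units; within the scatter) from compound 1 to compound 3 and a 1.1-fold higher number (0.04 log units; within the scatter) from compound 2 to compound 4, 1.8-fold (0.26 log units) apart, within the scatter of two such steps

Within these two pairs, the change therefore carries from one core to the other as a step that stays inside the scatter, and neither core offers a gain that could be relied on. This does not show that the change is without effect in general: two pairs cannot separate a small real effect from the scatter, nor can they show how the change would behave on any other core.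

The compounds shown carry only chloro or iodo at this aromatic carbon, which leaves open whether a different group there, such as fluoro, bromo, a nitrile or an amine, would move the number beyond the scatter. Also open, going by these compounds, is whether the exchange of chloro for iodo would remain this small on a core carrying a longer chain or a carboxylic acid.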